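Benzyl ether truncation in a fused bicyclic ether series

A few compounds are considered here, and "the series" means these few. Any claim that something is new, unique, unknown or untested is made for them only; others in the source may bear on it.

Measured compounds:
compound 1 `COc1cc(OCc2ccccc2OC)c2cc(-c3cn4nc(OC)sc4n3)oc2c1`, > 1000 nM
compound 2 `COc1cc(OCc2cccc(C#N)c2)c2cc(-c3cn4nc(OC)sc4n3)oc2c1`, 820 nM

Going by the values given here, in an assay on a cell-free system (plasma) for antagonist activity at proteinase-activated receptor 4 (Homo sapiens), with a stated time of 5 min, in the presence of a further agent that is not named here (on this read-out lower numbers stand for stronger inhibition and higher numbers for weaker inhibition), compound 2 gives 820 nM, the only numerical value in the set. Compound 1, in this assay, gives only a limit, > 1000 nM. Among the compounds with values here, the one measured step, an at least 1.2-fold lower number from compound 1 to compound 2 (0.08 log units; that floor lies within the scatter), is bounded on its lower side by the limit of > 1000 nM in this assay, at which 1 of the 2 values shown sits, and cannot be sized further. Compound 3 `COc1cc(OC)c2cc(-c3cn4nc(OC)sc4n3)oc2c1` differs from compound 2 by hydrogen in place of 3-cyanophenyl on a saturated chain carbon bound to an oxygen on an aromatic ring. Within the data shown here, no measured step removes this group; the step from compound 1 to compound 2 only exchanges one aryl for another, so it does not bear directly on the truncation. With the aryl group gone, a weaker result in this assay is expected, of about a 3.0-fold higher number from compound 2 to compound 3 (0.48 log units; beyond the scatter), and the number may well return to a limit. Compound 3 is estimated at 2500 nM, expected within 700 nM to 10000 nM.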

Compound 3, half-maximal inhibitory concentration: 530 nM
The estimate for compound 3 lay 4.7-fold (0.67 log units) above the measured number; the whole stated range lies above it.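

In this assay, the 3-cyanophenyl group shows no requirement at this position: exchanging it for hydrogen, which turns (3-cyanobenzyl)oxy into methoxy, gives a 1.5-fold lower number from compound 2 to compound 3 (0.19 log units; within the scatter). The exchange of 2-methoxyphenyl for hydrogen gives an at least 1.8-fold lower number from compound 1 to compound 3 (0.27 log units; that floor lies within the scatter), and this size is only a floor. Compound 1 gives > 1000 nM, which is a limit of the assay and not a number: the limit of > 1000 nM in this assay, at which 1 of the 3 values shown sits.

The compounds shown leave open whether any group on this oxygen can move the result beyond the scatter in either direction, for example a longer chain such as ethyl or propyl, or a chain ending in an amine or a carboxylic acid. They also leave open whether the oxygen substituent is needed at all, which a free hydroxyl in place of the methoxy would address.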